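Solubility of a Methylpiperazinyl-Piperidine Pair and Its Homologue

A few compounds are considered here, and "the series" means these few. Any claim that something is new, unique, unknown or untested is made for them only; others in the source may bear on it.

Compound 1 `CN1CCN(C2CCN(c3nccc4[nH]c(-c5cccc(OC(F)(F)F)c5)nc34)CC2)CC1`: 190000 nM
Compound 2 `CN1CCN(C2CCN(c3nccc4[nH]c(C5CCCC5)nc34)CC2)CC1`: 170000 nM

In a physicochemical assay for solubility, read by HPLC, using the shake flask method, in phosphate buffer, with a stated time of 20 h, at pH 6.5 (on this read-out lower numbers stand for lower solubility and higher numbers for higher solubility), compound 1 gives 190000 nM, and compound 2 gives 170000 nM. Compound 2 thus stands at the lowest of the two numbers, with compound 1 its nearest neighbour, and the step of a 1.1-fold lower number from compound 1 to compound 2 (0.05 log units; within the scatter) lies within the scatter, so the two are not told apart by this assay.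

Compound 3 `CN1CCN(CC2CCN(c3nccc4[nH]c(C5CCCC5)nc34)CC2)CC1` differs from compound 2 at one place: (4-methylpiperazin-1-yl)methyl in place of 4-methylpiperazin-1-yl on a saturated ring carbon. For the measured compounds named here, this change is not covered by any measured step; the only step in hand, a 1.1-fold lower number from compound 1 to compound 2 (0.05 log units; within the scatter), concerns a different position and was itself within the scatter. There is therefore no measured basis for expecting a shift beyond the scatter in this assay, and the expected step from compound 2 to compound 3 is no change at the digits printed from compound 2 to compound 3 (within the scatter), which is within the scatter. On that footing, compound 3 is estimated to give 170000 nM in this assay, with an expected range from 85000 nM to 340000 nM.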

Compound 3, solubility: < 5000 nM
Compound 3: only a limit was reported; the forecaster's own chance of this, stated with the estimate: 5%; middle value at least 34-fold (1.53 log units) away from the limit.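

The saturated ring carbon, three ring bonds from the ring nitrogen, turns out to be a position at which a small change registers strongly: with the cyclopentyl group held constant, (4-methylpiperazin-1-yl)methyl in place of 4-methylpiperazin-1-yl gives an at least 34-fold lower number from compound 2 to compound 3 (1.53 log units; beyond the scatter) in this assay. The two groups share the same six-membered ring and the same hydrogen-bond counts, and the entering group has 8 heavy atoms against 7 in the group it replaces. The only earlier step, a 1.1-fold lower number from compound 1 to compound 2 (0.05 log units; within the scatter), concerned a group on an aromatic carbon, so this is the first change among these compounds that this assay tells apart.

As far as these compounds go, the full size of the step and its cause stay open, since compound 3 is reported only as a limit: the limit of < 5000 nM in this assay, at which 1 of the 3 values shown sits. It also remains open whether the step would hold with the 3-(trifluoromethoxy)phenyl group of compound 1 in place of cyclopentyl, and how a longer chain between the piperidine-type ring and the piperazine, or a carboxylic acid at this ring carbon, would read in this assay.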